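The source may hold more compounds than are shown below. What is called first, only, known or untested is meant among the compounds shown, and "the series" means these compounds.

The three compounds measured in a functional assay on A549 cells (Homo sapiens) for inhibition, read by CCK-8 assay, with a stated time of 48 h (a higher number here means a weaker inhibitor, a lower number a stronger inhibitor), are:

compound 1, `COc1ccc(-c2cc3nccc(-c4cc(OC)c(OC)c(OC)c4)n3n2)cc1N`: 138 nM
compound 2, `COc1cc(-c2ccnc3cc(-c4ccc(C(C)=O)cc4)nn23)cc(OC)c1OC`: 4100 nM
compound 3, `COc1cc(-c2ccnc3cc(-c4ccc5ccn(C)c5c4)nn23)cc(OC)c1OC`: 829 nM

Compound 2 stands highest of the three numbers, that is, it is the weakest inhibitor of the set. The widest gap in the set is a 30-fold higher number from compound 1 to compound 2 (1.47 log units; beyond the scatter); the nearest neighbour of compound 2 is reached by a 4.9-fold lower number from compound 2 to compound 3 (0.69 log units; beyond the scatter), and the remaining step, a 6.0-fold higher number from compound 1 to compound 3 (0.78 log units; beyond the scatter), also lies beyond the scatter.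

Compound 4, `CCOC(=O)c1ccc(-c2cc3nccc(-c4cc(OC)c(OC)c(OC)c4)n3n2)cc1`, differs from compound 2 in one place: ethoxy in place of methyl on a carbonyl carbon. Within the data shown here, none of the measured steps bears on this kind of change. Each of them exchanges the whole aromatic group attached to the shared core, whereas the change to compound 4 leaves that group in place and alters only the substituent on its carbonyl carbon. Among the measured compounds shown here, there is therefore no measured step from which a direction can be read, and the expected step of a 1.0-fold lower number from compound 2 to compound 4 (0.01 log units; within the scatter) is one within the scatter. Compound 4 is accordingly estimated at 4000 nM, with a range from 1500 nM to 11000 nM in this assay.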

Compound 4, half-maximal inhibitory concentration: > 10000 nM
Compound 4: a limit, no number; the forecaster's own chance of this, stated with the estimate: 10%; at least 2.5-fold (0.39 log units) between middle value and limit.
By their numbers in this assay, from the lowest: compound 1; then compound 3; then compound 2. At a limit, above all of these: compound 4.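

In this assay, compound 4 gives a limit and not a number: the limit of > 10000 nM in this assay, at which 1 of the 4 values shown sits. The change from acetyl to ethoxycarbonyl gives an at least 2.4-fold higher number from compound 2 to compound 4 (0.38 log units; beyond the scatter), so only a minimum size can be read for this step. The earlier steps shown here all exchanged the whole aromatic group on the shared core, whereas this one shows that replacing methyl with ethoxy on the carbonyl carbon is enough on its own to move the number beyond the scatter, towards a weaker inhibitor.

The compounds shown leave open how a carboxylic acid or an amide at this carbonyl carbon would read in this assay, and whether an ester with a longer chain would follow ethoxy. They also leave open whether the same exchange would give a step of this direction on the 3-amino-4-methoxyphenyl group of compound 1, which carries no carbonyl.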